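The source may report more compounds than this note shows. Statements on the series, on what has been measured and on what is new or still open speak of the compounds shown alone.

Three compounds of the shared core have been run so far in a functional assay on MCF7 cells (Homo sapiens) for antiproliferative activity, read by sulforhodamine B assay, with a stated time of 72 h, tested at 30 uM; a higher number here means a weaker effect of the compound at the concentration tested, a lower number a stronger effect. Compound 1 `COC(=O)C1=C(N)Oc2ccc(Br)cc2C1CC(=O)c1ccc(Br)cc1` gives 34.8%. Compound 2 `COc1cc(Br)cc2c1OC(N)=C(C#N)C2CC(=O)c1ccc(Br)cc1` gives 33.1% in this assay. Compound 3 `COc1cccc(C(=O)CC2C(C#N)=C(N)Oc3ccc(Br)cc32)c1` gives 34.4% in this assay. On these numbers compound 3 sits among the other two: its nearest neighbour is compound 1, and the gap between them lies within the usual scatter; its furthest is compound 2, and that gap also lies within the scatter. For the measured compounds named here, no two of the measured compounds differ in only one place, so no step between measured compounds is recorded.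

Compound 4 `N#CC1=C(N)Oc2ccc(Br)cc2C1CC(=O)c1ccc(Br)cc1` is the next to be measured in this assay. It differs from compound 3 in one place: 4-bromophenyl in place of 3-methoxyphenyl on a carbonyl carbon. The three measured compounds all sit within the scatter of one another. The expected step from compound 3 to compound 4 is accordingly none beyond the scatter, in either direction, and is estimated as a number 0.4 percentage points lower from compound 3 to compound 4 (within the scatter). Compound 4 is estimated at 34%, with a range from 24% to 44%.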

Compound 4, a percentage reported as activity, at one concentration (the size of the read-out at that concentration, not a potency): 34.2%
Compound 4: the middle estimate sits 0.2 percentage points below what was measured, and the stated range covers the measured number.
By their numbers in this assay, from the lowest: compounds 2, 4, 3 and 1 (each within the scatter of the next).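

For the compounds shown here, on the carbonyl carbon, 4-bromophenyl in place of 3-methoxyphenyl gives a number 0.2 percentage points lower from compound 3 to compound 4 (within the scatter) in this assay and provides the first direct reading of a single change at this place. Hydrogen in place of methoxy on an aromatic carbon gives a number 1.1 percentage points higher from compound 2 to compound 4 (within the scatter) and cyano in place of methoxycarbonyl on a double-bonded ring carbon gives a number 0.6 percentage points lower from compound 1 to compound 4 (within the scatter) and so these two places also have direct readings. Compound 4 thus links the three earlier compounds by single changes, none beyond the scatter, and no measurement at hand bears on these readings.

On these data alone, it remains open whether an amine or a longer chain on the carbonyl carbon, or a carboxylic acid in place of methoxycarbonyl, would move the number beyond the scatter. Readings at a single concentration also leave potency differences within the series open.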